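Sulfone in place of thioether on the chain carbon

The source may report more compounds than this note shows. Statements on the series, on what has been measured and on what is new or still open speak of the compounds shown alone.

Compound 3 `CN(C)c1ccc(/C=C(/SCc2ccc(F)cc2)C(=O)c2ccc(Cl)cc2)cc1` gives 50000 nM in a functional assay on DU-145 cells (Homo sapiens) for inhibition, read by trypan blue exclusion, with a stated time of 96 h; a lower number here means a stronger inhibitor of growth, a higher number a weaker inhibitor of growth. Compound 2 `Cc1ccsc1/C=C(/SCc1ccc(F)cc1)C(=O)c1ccc(Cl)cc1` gives 50000 nM in this assay, and the step of no change at the digits printed from compound 2 to compound 3 (within the scatter) leaves the two level. Compound 1 `CN(C)c1ccc(/C=C(/Sc2ccc(Br)cc2)C(=O)c2ccc(Cl)cc2)cc1` reaches only a limit of this assay, > 100000 nM. Within the data shown here, the step of an at least 2.0-fold lower number from compound 1 to compound 3 (0.30 log units; that floor lies within the scatter) is the one change so far made on the sulfur substituent; its size is only a floor, since the limit of > 100000 nM in this assay, at which 1 of the 3 values shown sits, caps what the assay can report.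

The next step goes to compound 4 `Cc1ccc(S(=O)(=O)/C(=C/c2ccc(N(C)C)cc2)C(=O)c2ccc(Cl)cc2)cc1` with the change ((4-methylphenyl)sulfonyl in place of (4-fluorobenzyl)sulfanyl on a double-bonded chain carbon bound to a carbonyl carbon and a double-bonded chain carbon). Among the measured compounds shown here, no measured step swaps a sulfanyl for a sulfonyl, so the only step on the sulfur substituent, an at least 2.0-fold lower number from compound 1 to compound 3 (0.30 log units; that floor lies within the scatter), is the nearest guide, and it sets no more than a floor. The change from compound 2 to compound 3 on the other chain carbon moved nothing beyond the scatter. With every measured value sitting at or near the upper edge of this assay, compound 4 is expected to stay in the same weak region, and the step of a 1.2-fold higher number from compound 3 to compound 4 (0.08 log units; within the scatter) is estimated to lie within the scatter or to tilt toward a higher number. Compound 4 is therefore estimated at 60000 nM, with a range from 20000 nM to 150000 nM.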

Compound 4, concentration for 50% growth inhibition: > 100000 nM
Compound 4: a limit, no number (the forecaster's own chance of this, stated with the estimate: 35%); middle value at least 1.6-fold (0.22 log units) away from the limit.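

In this assay, replacing the thioether with a sulfone at this position gives an at least 2.0-fold higher number from compound 3 to compound 4 (0.30 log units; that floor lies within the scatter), so (4-methylphenyl)sulfonyl on the double-bonded chain carbon bound to a carbonyl carbon and a double-bonded chain carbon shows no sign of stronger growth inhibition than (4-fluorobenzyl)sulfanyl, and the true size of the step could exceed this floor. Compound 4 gives > 100000 nM, which is a limit and not a number. Among the groups compared at this position, only (4-fluorobenzyl)sulfanyl, in compound 2 and compound 3, has given a readable value, while the step between the two limited compounds, compound 1 and compound 4, cannot be read: the limit of > 100000 nM in this assay, at which 2 of the 4 values shown sit.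

The step from the thioether to the sulfone also replaces 4-fluorobenzyl with 4-methylphenyl on the sulfur, so the compounds shown do not separate the effect of the sulfone from that of the attached group; a (4-fluorobenzyl)sulfonyl group would address this directly. As far as these compounds go, whether an amine or a carboxylic acid on the group attached to the sulfur would bring a value clear of the limit also remains open.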